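The source may report more compounds than this note shows. Statements on the series, on what has been measured and on what is new or still open speak of the compounds shown alone.

Measured compounds:
- compound 1 `CC(C)[C@H](NC(=O)c1cc(Cl)ccc1OCCCNC(=O)OC(C)(C)C)C(=O)Nc1ccc([N+](=O)[O-])cc1Cl` — > 10000 nM (a limit)
- compound 2 `CC(C)[C@H](NC(=O)c1cc(Cl)ccc1OCCCN)C(=O)Nc1ccc([N+](=O)[O-])cc1Cl` — 6770 nM
- compound 3 `C[C@H](NC(=O)c1cc(Cl)ccc1OCCNC(=O)OC(C)(C)C)C(=O)Nc1ccc([N+](=O)[O-])cc1Cl` — > 10000 nM (a limit)

In a functional assay on MDA-MB-231 cells (Homo sapiens) for inhibition, read by MTT assay, with a stated time of 72 h (on this read-out lower numbers stand for stronger inhibition and higher numbers for weaker inhibition), compound 1 gives only a limit, > 10000 nM. Compound 2 carries the change hydrogen in place of tert-butoxycarbonyl on an amine nitrogen relative to compound 1, and in this assay compound 2 gives 6770 nM. The step of an at least 1.4-fold lower number from compound 1 to compound 2 (0.16 log units; that floor lies within the scatter) is therefore only a floor, since compound 1 sits at the limit of > 10000 nM in this assay, at which 2 of the 3 values shown sit.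

Compound 3 also gives only a limit in this assay, > 10000 nM. How the core of compound 3 differs from the core of compound 1 is not broken down here.

Compound 4 `C[C@H](NC(=O)c1cc(Cl)ccc1OCCN)C(=O)Nc1ccc([N+](=O)[O-])cc1Cl` is not yet measured. It stands to compound 3 as compound 2 stands to compound 1: the change hydrogen in place of tert-butoxycarbonyl on an amine nitrogen is the same change, with the same place on an amine nitrogen whose other neighbours are a saturated chain carbon. Compound 1 reached only a limit in this assay, > 10000 nM. Compound 2 gave 6770 nM in this assay. On that basis the expected step of an at least 1.2-fold lower number from compound 3 to compound 4 (0.09 log units; that floor lies within the scatter) is a small one, with a fair chance that compound 4 also returns only a limit. Compound 4 is estimated at 8000 nM, between 3500 nM and 20000 nM.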

Compound 4, half-maximal inhibitory concentration: > 10000 nM
Compound 4: no number, only a limit; the forecaster's own chance of this, stated with the estimate: 45%; middle value at least 1.2-fold (0.09 log units) from the limit.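

Compound 3 and compound 4 both return only limits, so no step can be read between them: the limit of > 10000 nM in this assay, at which 3 of the 4 values shown sit.

The compounds shown leave open where compound 3 and compound 4 truly lie, and so whether hydrogen in place of tert-butoxycarbonyl on an amine nitrogen changes the read-out at all in this pair.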